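A few compounds are considered here, and "the series" means these few. Any claim that something is new, unique, unknown or untested is made for them only; others in the source may bear on it.

Compound 1 `O=[N+]([O-])c1ccc(S(=O)(=O)C(F)F)cc1`: in a physicochemical assay for lipophilicity, read by spectrophotometry, using the shake flask method, measured as octanol-water partition (on this read-out lower numbers stand for lower lipophilicity and higher numbers for higher lipophilicity), compound 1 gives 1.7.
Compound 2 `FC(F)SCCc1ccccc1`: in this assay compound 2 gives 3.16.
Compound 3 `COCCc1ccccc1`: in this assay compound 3 gives 2.23.

Compound 3 stands second highest of the three numbers: compound 1 lies below it, compound 2 above it, both beyond the scatter. Compound 4 `CS(=O)(=O)CCc1ccccc1` differs from compound 3 by methylsulfonyl in place of methoxy on a saturated chain carbon, two bonds along the chain from an aromatic carbon. Within the data shown here, the only measured step at this same chain position is a number 0.93 log units lower from compound 2 to compound 3 (beyond the scatter), a modest fall. Among the measured compounds shown here, no measured pair shows a methylsonyl entering, so the expectation for compound 4 rests on compound 3 alone, with the measured step as a guide to size. A fall beyond the scatter is expected, a number 1.23 log units lower from compound 3 to compound 4 (beyond the scatter). Compound 4 is estimated at 1, within 0.5 to 1.5.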

Compound 4, partition coefficient: 0.82
The estimate for compound 4 lay 0.18 log units above the measured number; low and high end bracket the measured number.
By their numbers in this assay, from the lowest: compound 4; then compound 1; then compound 3; then compound 2.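

In this assay, methylsulfonyl in place of methoxy gives a number 1.41 log units lower from compound 3 to compound 4 (beyond the scatter) at this chain position, a large step where the earlier one was modest. Measured against (difluoromethyl)sulfanyl, the same group gives a number 2.34 log units lower from compound 2 to compound 4 (beyond the scatter) in that assay, so the three groups on this chain now fall in the order (difluoromethyl)sulfanyl, methoxy, methylsulfonyl. Nothing available accounts for the size of these steps. The compounds shown leave open where methylsulfanyl or methylsulfinyl would fall at this position. They also leave open whether the step from methoxy to methylsulfonyl keeps its size on a longer chain.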